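From methoxy to (oxolan-3-yl)oxy in the amide series

This account rests on a few compounds, and the source may have more. Where it says the series, first, only, none or still open, it means among the compounds named here.

In a functional assay on MCF7 cells (Homo sapiens) for cytotoxicity, read by MTT assay, with a stated time of 72 h (a lower number here means a stronger inhibitor, a higher number a weaker inhibitor), compound 1 (`COc1cc2ncnc(Nc3ccc(F)c(Cl)c3)c2cc1NC(=O)/C=C/c1ccc(F)cc1Cl`) gives "not active" (no number reported) with no number reported. Compound 2 (`COc1cc2ncnc(Nc3ccc(F)c(Cl)c3)c2cc1NC(=O)/C=C/c1ccccc1[N+](=O)[O-]`) gives 36500 nM and compound 3 (`COc1ccc(/C=C/C(=O)Nc2cc3c(Nc4ccc(F)c(Cl)c4)ncnc3cc2OC)c(OC)c1`) gives 36600 nM in the same test. For the measured compounds named here, compound 2 therefore stands level with compound 3, the only other compound with a number.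

Compound 4 (`O=C(/C=C/c1ccccc1[N+](=O)[O-])Nc1cc2c(Nc3ccc(F)c(Cl)c3)ncnc2cc1O[C@H]1CCOC1`) differs from compound 2 by one change (oxolan-3-yl in place of methyl on an oxygen on an aromatic ring) with oxolan-3-yl in place of methyl on an oxygen on an aromatic ring. Going by the values given here, no measured step alters the group on that oxygen, so the data give no direct size for this change. Among the compounds with values here, the one measured step (a 1.0-fold higher number from compound 2 to compound 3 (0.00 log units; within the scatter)) replaces 2-nitrophenyl with 2,4-dimethoxyphenyl elsewhere in the structure and lies within the scatter. It bears on the present change only indirectly, and compound 1 shows that not every compound in the series returns a number. No shift beyond the scatter is expected in this assay, and a report without a number remains possible. The estimated change is a 1.2-fold lower number from compound 2 to compound 4 (0.09 log units; within the scatter) and this expected step stays within the scatter. For compound 4 the expected value is 30000 nM with an estimated range from 10000 nM to 70000 nM in this test.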

Compound 4, half-maximal inhibitory concentration: 28400 nM
Beside the measured number, compound 4's estimate is 1.1-fold (0.02 log units) above it; the range from low to high includes it.
By their numbers in this assay, from the lowest: compounds 4, 2 and 3 (each within the scatter of the next).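

In this assay, for the compounds shown here, the exchange of methoxy for (oxolan-3-yl)oxy gives a 1.3-fold lower number from compound 2 to compound 4 (0.11 log units; within the scatter) and so stays within the scatter, the first measured step at this oxygen on the aromatic ring. Going by these compounds alone, the only earlier step concerned the aryl group on the double-bonded chain and said nothing directly about this oxygen. Within this single pair, the read-out holds level even though 5 heavy atoms enter where 1 leaves, bringing one five-membered non-aromatic ring, 1 hydrogen-bond acceptor and 1 defined stereocentre; with no supporting evidence, the compounds shown give no explanation for this flat step.

The compounds shown leave open whether (oxolan-3-yl)oxy would stay level with methoxy on the 2,4-dimethoxyphenyl amide of compound 3, or would change the report without a number for compound 1. Also open, as far as these compounds go, are the opposite configuration at the stereocentre and other groups on this oxygen, such as a 2-methoxyethyl chain, a piperidin-4-yl ring or a chain ending in a dimethylamino group.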